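The source may hold more compounds than are shown below. What is called first, only, known or untested is meant among the compounds shown, and "the series" means these compounds.

The measured compounds, tested in a functional assay on U-87MG ATCC cells (Homo sapiens) for cytotoxicity, read by MTT assay, with a stated time of 24 h; on this read-out higher numbers stand for weaker inhibition and lower numbers for stronger inhibition:

compound 1, `CCCCCCCCCCCC(=O)Nc1cn(-c2ccccc2)nc1-c1ccccc1`: 81000 nM
compound 2, `O=C(CCCCCCCCCCS)Nc1cn(-c2ccccc2)nc1-c1ccccc1`: 90000 nM
compound 3, `CCCCCCCCCCCC(=O)Nc1cn(C)nc1-c1ccccn1`: a limit, > 150000 nM

Compound 1 and compound 2 share a core and differ in one place only: sulfanyl in place of methyl on a saturated chain carbon, ten or more bonds along the chain from a carbonyl carbon. The step this made, a 1.1-fold higher number from compound 1 to compound 2 (0.05 log units; within the scatter), lies within the scatter of repeated measurements, so the two values cannot be told apart. Compound 3 carries a different core; how the two cores differ is not broken down here. In this assay compound 3 gives no number at all, only a limit, > 150000 nM; this is the limit of > 150000 nM in this assay, at which 1 of the 3 values shown sits.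

Compound 4, `Cn1cc(NC(=O)CCCCCCCCCCS)c(-c2ccccn2)n1`, is built from compound 3 by the same kind of change: sulfanyl in place of methyl on a saturated chain carbon, ten or more bonds along the chain from a carbonyl carbon. The place is described in the same words for both pairs. The earlier step, a 1.1-fold higher number from compound 1 to compound 2 (0.05 log units; within the scatter), stayed within the scatter, and on that rests the expectation of a similarly small step here, a step that the limit leaves unreadable from compound 3 to compound 4. Compound 4 is therefore estimated to land at about 160000 nM, somewhere between 80000 nM and 320000 nM, and most likely the assay will again report only a limit rather than a number.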

Compound 4, half-maximal inhibitory concentration: > 150000 nM
Compound 4 was reported as a limit; the forecaster's own chance of this, stated with the estimate: 70%; the middle value is on the limit's open side.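

In this assay compound 4 gives only a limit, > 150000 nM, and compound 3 is reported as a limit too, so no step can be read between these two compounds: the limit of > 150000 nM in this assay, at which 2 of the 4 values shown sit.

The compounds shown leave open how far past that limit compound 3 and compound 4 lie, and whether sulfanyl in place of methyl changes the read-out at all on their shared core.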